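This account rests on a few compounds, and the source may have more. Where it says the series, first, only, none or still open, it means among the compounds named here.

Measured in a functional assay on ECa-109 cells for inhibition, with ECa-109 cell line (Homo sapiens) as the target, read by MTT assay, with a stated time of 48 h; on this read-out lower numbers stand for stronger inhibition and higher numbers for weaker inhibition:
- compound 1 (`COc1ccc(Nc2nnc(Cl)c(Nc3cc(OC)c(OC)c(OC)c3)n2)cc1`): 22300 nM
- compound 2 (`COc1cc(Nc2nc(Nc3ccc(C)cc3)nnc2Cl)cc(OC)c1OC`): 27300 nM
- compound 3 (`COc1cc(Nc2nc(Nc3ccccc3)nnc2Cl)cc(OC)c1OC`): 12600 nM

Compound 3, at 12600 nM, cannot be told apart from compound 1 (a 1.8-fold lower number from compound 1 to compound 3 (0.25 log units; within the scatter)). It stands clear only of compound 2 (a 2.2-fold lower number from compound 2 to compound 3 (0.34 log units; beyond the scatter)), and that gap is modest.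

Compound 4 (`COc1cc(Nc2nc(Nc3ccc4c(ccn4C)c3)nnc2Cl)cc(OC)c1OC`) carries a larger change, 1-methyl-1H-indol-5-yl in place of phenyl on a nitrogen on an aromatic ring. The measured steps bear on this only loosely. Each swaps a small group on an aromatic carbon, and the remaining one, a 1.2-fold higher number from compound 1 to compound 2 (0.09 log units; within the scatter), is also small. Among the compounds with values here, none of the compounds measured so far carries a 1-methyl-1H-indol-5-yl group, so the direction is uncertain, and a modest move towards a lower number is only a tentative expectation. The expected step is a 2.1-fold lower number from compound 3 to compound 4 (0.32 log units; beyond the scatter), with a wide margin. Compound 4 is estimated at 6000 nM, with an expected range from 1000 nM to 25000 nM.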

Compound 4, half-maximal inhibitory concentration: 42100 nM
For compound 4 the middle estimate is 7.0-fold (0.85 log units) below the measured one; measured number above the stated range.
By their numbers in this assay, from the lowest: compounds 3, 1, 2 and 4 (each within the scatter of the next, the first and the last beyond it).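

In this assay, within the data shown here, the first two-ring group on this nitrogen on an aromatic ring, 1-methyl-1H-indol-5-yl, gives weaker inhibition than plain phenyl (a 3.3-fold higher number from compound 3 to compound 4 (0.52 log units; beyond the scatter)), a modest step. Set against the substituted phenyl groups, it cannot be told apart from 4-methylphenyl (a 1.5-fold higher number from compound 2 to compound 4 (0.19 log units; within the scatter)) or from 4-methoxyphenyl (a 1.9-fold higher number from compound 1 to compound 4 (0.28 log units; within the scatter)), so at this position the larger group offers no measurable advantage over either, and only unsubstituted phenyl stands clear of it. Nothing available here accounts for the step from phenyl to this group.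

Going by these compounds, it remains open whether 1H-indol-5-yl, without the methyl on its nitrogen, would read differently from compound 4. On these data alone, it is equally open how an amine or a carboxylic acid on the phenyl ring would behave at this position.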